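Adding fluoro to compound 3: what to expect

The compounds below may be only part of what the source reports. "The series", "measured", "known", "first", "only" and "open" are said of these compounds alone.

Values so far in an ADME assay on Vero cells (Chlorocebus sabaeus) for cytotoxicity, read by MTT assay, with a stated time of 72 h (on this read-out higher numbers stand for lower toxicity in this test and lower numbers for higher toxicity in this test), for three compounds
Compound 1 `COc1c(N2C[C@H]3CCCN(C(=O)Cn4cc(CN5C(=O)/C(=N/O)c6cc(F)ccc65)nn4)[C@H]3C2)c(F)cc2c(=O)c(C(=O)O)cn(C3CC3)c12` gives 16 ug/mL
Compound 2 `CO/N=C1/C(=O)N(Cc2cn(CC(=O)N3CCC[C@@H]4CN(c5c(F)cc6c(=O)c(C(=O)O)cn(C7CC7)c6c5OC)C[C@@H]43)nn2)c2ccc(F)cc21` gives 32 ug/mL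
Compound 3 `COc1c(N2C[C@H]3CCCN(C(=O)Cn4cc(CN5C(=O)/C(=N/NC(N)=S)c6ccccc65)nn4)[C@H]3C2)c(F)cc2c(=O)c(C(=O)O)cn(C3CC3)c12` gives 16 ug/mL

Compound 3 shows the same number as compound 1, and compound 2 lies within the usual scatter of both. Compound 4 `COc1c(N2C[C@H]3CCCN(C(=O)Cn4cc(CN5C(=O)/C(=N/NC(N)=S)c6cc(F)ccc65)nn4)[C@H]3C2)c(F)cc2c(=O)c(C(=O)O)cn(C3CC3)c12` has not yet been measured. It carries one change from compound 3 (fluoro in place of hydrogen on an aromatic carbon), a fluoro in place of hydrogen on an aromatic carbon.

Going by the values given here, the only measured step, a 2.0-fold higher number from compound 1 to compound 2 (0.30 log units; within the scatter), is a different change, methyl in place of hydrogen on an oxygen, and it stays within the scatter. Among the compounds with values here, no measured step isolates the fluoro. Compound 1 has this fluoro and compound 3 lacks it, but the two also differ elsewhere, and compound 1 at 16 ug/mL and compound 3 at 16 ug/mL read alike. Nothing here points to a step beyond the scatter in this assay for this change. The expected step is no change at the digits printed from compound 3 to compound 4 (within the scatter), no more than the scatter. Compound 4 is estimated at 16 ug/mL, with an expected range from 8 ug/mL to 32 ug/mL in repeat measurements.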

Compound 4, half-maximal cytotoxic concentration: 8 ug/mL
Compound 4: the middle estimate sits 2.0-fold (0.30 log units) above what was measured, within the range that was stated.
By their numbers in this assay, from the lowest: compounds 4, 1, 3 and 2 (each within the scatter of the next, the first and the last beyond it).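

In this assay, going by these compounds alone, a 2.0-fold lower number from compound 3 to compound 4 (0.30 log units; within the scatter) is the first reading of this change on its own: fluoro in place of hydrogen on this aromatic carbon gives no step beyond the scatter. With the fluoro present in all three compounds, the group on the double-bonded nitrogen can now be compared, and a 2.0-fold lower number from compound 1 to compound 4 (0.30 log units; within the scatter) also stays within the scatter. In contrast, a 4.0-fold lower number from compound 2 to compound 4 (0.60 log units; beyond the scatter) is a modest step and the only new one beyond the scatter, while no measured evidence here accounts for any of these steps.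

The compounds shown carry only hydrogen or fluoro at this aromatic carbon, so how a chloro group or an amine there would read remains open. As far as these compounds go, whether fluoro gives a similar step alongside the groups on the double-bonded nitrogen of compound 1 and compound 2 also remains open.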